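The compounds below may be only part of what the source reports. "The series", "measured", "known", "first", "only" and "open" are said of these compounds alone.

Of the compounds shown here, three have been tested in a functional assay on the whole organism (Tail, strain ICR) with Mus musculus as the target, in the tail flick test, with a stated time of 30 min, at a dose of 25 umol/kg by the oral route; on this read-out higher numbers stand for a stronger effect at the one dose given and lower numbers for a weaker effect. Compound 1 `NC(=O)CC[C@H](NC(=O)CN(c1ncnc2c1ncn2C1CCCCO1)C1CC1)C(=O)OCc1ccccc1` gives 47% in this assay, the highest of the three numbers, and its lead over both others is beyond the usual scatter of repeated measurements. Compound 2 `O=C(CN(c1nc(Cl)nc2[nH]cnc12)C1CC1)N[C@@H](CC(=O)OCc1ccccc1)C(=O)OCc1ccccc1` gives 34.7%, and compound 3 `O=C(O)CNC(=O)CN(c1nc(Cl)nc2[nH]cnc12)C1CC1` gives 32.2%. Compound 4 `NC(=O)C[C@H](NC(=O)CN(c1ncnc2c1ncn2C1CCCCO1)C1CC1)C(=O)OCc1ccccc1` has not yet been measured. It differs from compound 1 in a single place: carbamoyl in place of carbamoylmethyl on a saturated chain carbon, two bonds along the chain from an amide-type nitrogen and a carbonyl carbon. For the measured compounds named here, no two measured compounds differ in only one place, so the size of such a step cannot be read from the data at hand. A small downward step is expected, close to the edge of the scatter, so the estimated step of a number 7 percentage points lower from compound 1 to compound 4 (within the scatter) is modest. For compound 4 the expected value is 40%, with a range from 22% to 58%.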

Compound 4, a percentage reported as activity, at one dose (the size of the read-out at that dose, not a potency): 34.5%
Compound 4: middle estimate off by 5.5 percentage points, on the high side; the measured number falls inside the stated range.
By their numbers in this assay, from the lowest: compounds 3, 4 and 2 (each within the scatter of the next); then compound 1.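

For the compounds shown here, this is the first change in the set that can be read at a single place. In this assay, carbamoyl in place of carbamoylmethyl on this saturated chain carbon gives a number 12.5 percentage points lower from compound 1 to compound 4 (beyond the scatter), although the two groups differ only in their carbon count. Nothing at hand gives a reason for this drop.

Going by these compounds, whether a longer chain or a carboxylic acid at this place would raise or lower the number remains open. All other steps cannot be read, since compounds 2 and 3 differ from the rest in more than one place.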